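Extending the ether chain on a brominated catechol

This account rests on a few compounds, and the source may have more. Where it says the series, first, only, none or still open, it means among the compounds named here.

Three measured compounds share one core. Compound 1 `O=Cc1cc(Br)c(O)c(O)c1Br` carries a formyl group; in a functional assay on DLD-1 cells (Homo sapiens) for cytotoxicity, read by MTT assay, with a stated time of 96 h (on this read-out lower numbers stand for stronger inhibition and higher numbers for weaker inhibition), compound 1 gives 31000 nM. Compound 2 `COCc1cc(Br)c(O)c(O)c1Br` carries a methoxymethyl group instead, and in this assay compound 2 gives 7270 nM. Compound 3 `CCOCc1cc(Br)c(O)c(O)c1Br` carries an ethoxymethyl group, and in this assay compound 3 gives 7150 nM.

Compound 3 holds the lowest of the three numbers, but its neighbour compound 2 sits within the scatter of it, so the two cannot be ranked; the step of a 4.3-fold lower number from compound 1 to compound 3 (0.64 log units; beyond the scatter) is modest, much like a 4.3-fold lower number from compound 1 to compound 2 (0.63 log units; beyond the scatter).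

Compound 4 `CCCOCc1cc(Br)c(O)c(O)c1Br` differs from compound 3 by methyl in place of hydrogen on a saturated chain carbon, two bonds along the chain from an oxygen on a saturated carbon. For the measured compounds named here, the only measured step of the same kind is a 1.0-fold lower number from compound 2 to compound 3 (0.01 log units; within the scatter), which lay within the scatter. With a further methyl in place of hydrogen one bond further out, the step of a 1.1-fold lower number from compound 3 to compound 4 (0.04 log units; within the scatter) is expected to stay within the scatter in this assay. Compound 4 is therefore estimated at 6500 nM, with a likely range from 3000 nM to 15000 nM.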

Compound 4, half-maximal inhibitory concentration: 1720 nM
Compound 4: the middle estimate sits 3.8-fold (0.58 log units) above what was measured; measured number outside the range, below it.
By their numbers in this assay, from the lowest: compound 4; then compounds 3 and 2 (each within the scatter of the next); then compound 1.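

Within this assay, the chain on this ether does affect the number, but not evenly: adding a methyl gave a step within the scatter from compound 2 to compound 3, whereas the same kind of change further out gives a 4.2-fold lower number from compound 3 to compound 4 (0.62 log units; beyond the scatter) and so moves beyond it. The propoxy chain therefore separates itself from the shorter ethers, with a 4.2-fold lower number from compound 2 to compound 4 (0.63 log units; beyond the scatter) as the comparison with the methoxymethyl group, and the replacement of formyl now amounts to an 18-fold lower number from compound 1 to compound 4 (1.26 log units; beyond the scatter) as the largest step in the set. Nothing available here explains why the drop appears only at this chain length.

A butoxymethyl or longer chain could continue the fall or level it off. On these data alone, it also remains open whether a branched isopropoxymethyl group, or an aminomethyl group in place of the ether, would match the propoxymethyl compound.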